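Phenyl in Place of Cyano on the Carbonyl-Side Ring

The compounds below may be only part of what the source reports. "The series", "measured", "known", "first", "only" and "open" are said of these compounds alone.

Compound 1 `COc1cc(OC)cc(C(=O)Nc2cccc(-c3oc4cc(-c5ccc(F)cc5)ccc4c(=O)c3O)c2)c1`: 2390 nM
Compound 2 `N#Cc1ccc(C(=O)Nc2cccc(-c3oc4cc(-c5ccc(F)cc5)ccc4c(=O)c3O)c2)cc1`: 2360 nM

In a functional assay on A549 cells (Homo sapiens) for antiproliferative activity, read by CCK-8 assay, with a stated time of 72 h (a lower number here means a stronger inhibitor, a higher number a weaker inhibitor), compound 1 gives 2390 nM and compound 2 gives 2360 nM. Among the compounds with values here, the single step between them, a 1.0-fold lower number from compound 1 to compound 2 (0.01 log units; within the scatter), replaced 3,5-dimethoxyphenyl with 4-cyanophenyl on the carbonyl carbon and lies within the scatter. Compound 2 shows the lowest of the two numbers, with compound 1 nearest, and the two are within the scatter of each other, so no order is claimed.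

Compound 3 `O=C(Nc1cccc(-c2oc3cc(-c4ccc(F)cc4)ccc3c(=O)c2O)c1)c1ccc(-c2ccccc2)cc1` differs from compound 2 by phenyl in place of cyano on an aromatic carbon; cut one bond further out, this reads 4-cyanophenyl to 4-phenylphenyl. Within the data shown here, the only measured step that touches this position, the exchange of the aryl group on the carbonyl carbon from compound 1 to compound 2, produced no step beyond the scatter. That step, however, did not add a ring, so it bears only loosely on the present change. With this in mind, compound 3 is estimated at 2400 nM, with a range from 800 nM to 7000 nM. The estimated step of a 1.0-fold higher number from compound 2 to compound 3 (0.01 log units; within the scatter) is expected to stay within the scatter, with the wide range reflecting how little the measured steps constrain it.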

Compound 3, half-maximal inhibitory concentration: > 100000 nM
Compound 3 gave a limit, no number; the forecaster's own chance of this, stated with the estimate: 10%; at least 41-fold (1.61 log units) between middle value and limit.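

In this assay compound 3 reads only as a limit, not as a number: the limit of > 100000 nM in this assay, at which 1 of the 3 values shown sits.

The aryl group on the carbonyl carbon is therefore not indifferent to every exchange: the earlier exchange gave a 1.0-fold lower number from compound 1 to compound 2 (0.01 log units; within the scatter), whereas phenyl in place of cyano gives an at least 42-fold higher number from compound 2 to compound 3 (1.62 log units; beyond the scatter), and 4-phenylphenyl in place of 3,5-dimethoxyphenyl gives an at least 41-fold higher number from compound 1 to compound 3 (1.62 log units; beyond the scatter). Of the three compounds, 4-cyanophenyl and 3,5-dimethoxyphenyl both keep a measurable value, and only 4-phenylphenyl, with its added six-membered aromatic ring, does not.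

The compounds shown leave open whether the aromatic ring itself is what separates compound 3 from compound 2, or whether a cyclohexyl ring or a longer chain in the same place would do the same. They also leave open how a small group there, such as a methoxy group or an amine, would read.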